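This account rests on a few compounds, and the source may have more. Where it says the series, first, only, none or still open, it means among the compounds named here.

Compound 1, with the structure `CC(C)CCn1c(Cn2c(=O)n(C(C)C)c3ccccc32)nc2cc(CN)ccc21`, is the starting point of this comparison. Among the measured compounds shown here, in an ADME assay on HEp-2 cells (Homo sapiens) for cytotoxicity (a lower number here means that less compound is tolerated, a higher number that more compound is tolerated), compound 1 gives 3920 nM, the lowest of the two numbers measured so far. For the measured compounds named here, compound 2, with the structure `CC(C)CCn1c(Cn2c(=O)n(C(C)C)c3ccccc32)nc2ccc(CN(C)C)cc21`, is the only other measured compound; in this assay compound 2 gives 26700 nM, a number that lies beyond the scatter above compound 1. Going by the values given here, compound 2 differs from compound 1 in more than one place, so its values show only that a higher number is possible.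

Compound 3, with the structure `C=Cc1ccc2c(c1)nc(Cn1c(=O)n(C(C)C)c3ccccc31)n2CCC(C)C`, has not yet been measured. It differs from compound 1 in a single way: vinyl in place of aminomethyl on an aromatic carbon. Among the compounds with values here, no measured step of this kind exists among the compounds here, so the expectation rests on the change alone. For compound 3 a small step toward a higher number is expected, a 1.5-fold higher number from compound 1 to compound 3 (0.18 log units; within the scatter), not clearly beyond the scatter. Compound 3 is therefore estimated at 6000 nM, within a range from 2000 nM to 18000 nM.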

Compound 3, half-maximal cytotoxic concentration: 6520 nM
Beside the measured number, compound 3's estimate is 1.1-fold (0.04 log units) below it; low and high end bracket the measured number.
By their numbers in this assay, from the lowest: compounds 1 and 3 (each within the scatter of the next); then compound 2.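

In this assay, putting vinyl in place of aminomethyl on this aromatic carbon gives a 1.7-fold higher number from compound 1 to compound 3 (0.22 log units; within the scatter), so the two compounds cannot be told apart in this assay. Among the compounds shown here, this is the first comparison that changes only one place, and it shows that at this position, losing the nitrogen, the hydrogen-bond donor and the hydrogen-bond acceptor counted for aminomethyl goes with no shift beyond the usual scatter. Nothing shown here gives a reason for this result.

From the compounds shown here alone, whether a carboxylic acid or a longer carbon chain on the same aromatic carbon would also stay within the scatter remains open. Going by these compounds, compound 2 differs from compound 1 and compound 3 in more than one place, so which of its features goes with its number also remains open.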